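Notes on the series: from compound 2 toward compound 4

The compounds below may be only part of what the source reports. "The series", "measured", "known", "first", "only" and "open" are said of these compounds alone.

Compound 1 `Fc1ccccc1/C=C/c1ccccc1` gives 700 nM in an assay on HepG2 cells for activation of nuclear factor erythroid 2-related factor 2 (Homo sapiens), read by a luciferase reporter, with a stated time of 5 h; on this read-out lower numbers stand for an effect already at smaller amounts and higher numbers for an effect only at larger amounts of compound. Compound 2 `COc1cccc(/C=C/c2ccccc2F)c1` gives 3800 nM in this assay. Compound 3 `Fc1cccc(/C=C/c2ccccc2F)c1` is reported only as a limit in this assay, > 15000 nM. The steps from the parent are a 5.4-fold higher number from compound 1 to compound 2 (0.73 log units; beyond the scatter) and an at least 21-fold higher number from compound 1 to compound 3 (1.33 log units; beyond the scatter), the latter resting on (the limit of > 15000 nM in this assay, at which 1 of the 3 values shown sits). Within the series compound 2 holds the highest of the two plain numbers; its nearest neighbour is compound 1, and the gap between them is a 5.4-fold higher number from compound 1 to compound 2 (0.73 log units; beyond the scatter).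

Compound 4 `COc1cccc(/C=C/c2ccccc2OC)c1` differs from compound 2 by methoxy in place of fluoro on an aromatic carbon. Going by the values given here, no measured step exchanges fluoro for methoxy at this carbon. The closest pointer is an at least 3.9-fold higher number from compound 2 to compound 3 (0.59 log units; beyond the scatter), where the opposite exchange at the other ring raised the number; read in reverse it suggests that methoxy in place of fluoro could lower the number, though the position differs and the transfer is uncertain. The step expected is therefore a 1.5-fold lower number from compound 2 to compound 4 (0.18 log units; within the scatter), a modest lowering or none beyond the scatter. The estimate for compound 4 in this assay is 2500 nM, within 600 nM to 10000 nM.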

Compound 4, half-maximal effective concentration: 4400 nM
For compound 4 the middle estimate is 1.8-fold (0.25 log units) below the measured one, within the range that was stated.
By their numbers in this assay, from the lowest: compound 1; then compounds 2 and 4 (each within the scatter of the next). At a limit, above all of these: compound 3.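

On an aromatic carbon ortho to a large group, methoxy in place of fluoro gives a 1.2-fold higher number from compound 2 to compound 4 (0.06 log units; within the scatter) in this assay, so in this pair the position takes either group with no shift that can be told from the scatter. The only earlier exchange between these two groups, fluoro in place of methoxy at a different aromatic carbon, gave an at least 3.9-fold higher number from compound 2 to compound 3 (0.59 log units; beyond the scatter), so the exchange does not read alike at the two carbons in the compounds shown. No measurement shown bears on the cause of this result.

As far as these compounds go, whether an amine or a carboxylic acid on this carbon would move the number beyond the scatter remains open. From the compounds shown here alone, a longer chain such as ethoxy in place of methoxy here is equally open, so the size of group this position takes is unsettled.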